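The source may report more compounds than this note shows. Statements on the series, on what has been measured and on what is new or still open speak of the compounds shown alone.

Measured so far in a functional assay on U2OS cells for antagonist activity at C-X-C chemokine receptor type 3 (Homo sapiens), read by beta-arrestin recruitment; a higher number here means a weaker inhibitor, a lower number a stronger inhibitor:
compound 1 `C[C@@H]1CN(c2sc(CO)nc2-c2nc3ccccc3[nH]2)CCN1C(=O)Cn1cnc2cccnc21`: > 10000 nM
compound 2 `CCCc1ncc(-c2nc(C(F)(F)F)sc2N2CCN(C(=O)Cn3cnc4cccnc43)[C@H](C)C2)cn1`: 33 nM
compound 3 `CCOc1ncc(-c2nc(C(F)(F)F)sc2N2CCN(C(=O)Cn3ccc4cccnc43)[C@H](C)C2)cn1`: 47 nM.

For compound 1 the value is a limit of the assay, (the limit of > 10000 nM in this assay, at which 1 of the 3 values shown sits), not a number. Among the two numbers compound 3 stands highest, with compound 2 a small gap lower, within the scatter, so no order between them is claimed. Compound 4 `CCOc1ncc(-c2nc(C(F)(F)F)sc2N2CCN(C(=O)Cn3ccc(C(F)(F)F)n3)[C@H](C)C2)cn1` differs from compound 3 in one place: a group of 9 heavy atoms (4 carbon, 2 nitrogen, 3 fluorine; one five-membered aromatic ring with 2 hetero atoms) in place of a group of 9 heavy atoms (7 carbon, 2 nitrogen; one five-membered aromatic ring with 1 hetero atom, one six-membered aromatic ring with 1 hetero atom), on a saturated chain carbon bound to a carbonyl carbon. Within the data shown here, no step between measured compounds covers this change. Since compound 2 at 33 nM and compound 3 at 47 nM carry different groups at this place and give values within the scatter of each other, only a modest step upward, beyond the scatter but small, is expected for compound 4, a 2.3-fold higher number from compound 3 to compound 4 (0.37 log units; beyond the scatter). Compound 4 is expected near 110 nM, within 30 nM to 400 nM.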

Compound 4, half-maximal inhibitory concentration: 93 nM
Compound 4: middle estimate off by 1.2-fold (0.07 log units), on the high side; the measured number falls inside the stated range.
By their numbers in this assay, from the lowest: compounds 2, 3 and 4 (each within the scatter of the next, the first and the last beyond it). At a limit, above all of these: compound 1.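

At this place, on a saturated chain carbon bound to a carbonyl carbon, 3-(trifluoromethyl)-1H-pyrazol-1-yl takes the place of a group with a five-membered and a six-membered aromatic ring in this assay, with a 2.0-fold higher number from compound 3 to compound 4 (0.30 log units; within the scatter). The six-membered aromatic ring is thus not required here to keep the value within the scatter, at least with trifluoromethyl on the five-membered ring. No measurement given here bears on the reason for this result.

Open, going by these compounds, is what a hydrogen, a methyl or a carboxylic acid would give in place of the trifluoromethyl. Also open, on these data alone, is how a simple amine would behave at this place.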